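Adding a Nitrile to the Ether-Linked Compound

This account rests on a few compounds, and the source may have more. Where it says the series, first, only, none or still open, it means among the compounds named here.

In a functional assay on HEK293 cells for negative allosteric modulation of metabotropic glutamate receptor 5 (Rattus norvegicus), read by FLIPR and calcium flux, with a stated time of 170 s (a higher number here means a weaker inhibitor, a lower number a stronger inhibitor), three compounds have been measured so far:
compound 1 `N#Cc1ccc(-c2cc3n(n2)CCCC3)nc1` gives > 10000 nM, a limit of the assay;
compound 2 `c1ccc(COc2cc3n(n2)CCCC3)nc1` gives 2500 nM;
compound 3 `Clc1ccnc(COc2cc3n(n2)CCCC3)c1` gives > 10000 nM, a limit of the assay.

Within the data shown here, compound 2 thus holds the only true number in the set. The other two values are limits, and the limit of > 10000 nM in this assay, at which 2 of the 3 values shown sit, marks where they sit. Among the measured compounds shown here, the single measured step that changes the six-membered ring of compound 2 is an at least 4.0-fold higher number from compound 2 to compound 3 (0.60 log units; beyond the scatter): chloro in place of hydrogen on an aromatic carbon weakened inhibition at least modestly. For the measured compounds named here, compound 1 also carries a cyano group but lacks the ether linker of compound 2, so no step connects the two. Compound 1 shows only a limit.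

Compound 4 `N#Cc1ccc(COc2cc3n(n2)CCCC3)nc1` differs from compound 2 by cyano in place of hydrogen on an aromatic carbon. The step from compound 2 to compound 3 bears on this change, as both place a small group on the same ring, and it reached at least the size shown. The step to compound 4 is therefore expected to run the same way, toward a weaker inhibitor, with a fair chance that only a limit is reported; the expected step is a 2.8-fold higher number from compound 2 to compound 4 (0.45 log units; beyond the scatter). Compound 4 is estimated at 7000 nM, within a range from 2500 nM to 20000 nM.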

Compound 4, half-maximal inhibitory concentration: 316 nM
For compound 4 the middle estimate is 22-fold (1.35 log units) above the measured one; the whole stated range lies above it.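

In this assay, cyano in place of hydrogen on an aromatic carbon, para to a large group and two atoms from the ring nitrogen, gives a 7.9-fold lower number from compound 2 to compound 4 (0.90 log units; beyond the scatter), so this position on the ring of compound 2 can carry a group with a gain in inhibition. Among these compounds, the only earlier measured change on this ring was an at least 4.0-fold higher number from compound 2 to compound 3 (0.60 log units; beyond the scatter), and with the two steps from compound 2 now running in opposite directions, a new group on this ring does not as such weaken inhibition. Compound 1, which also carries a cyano group but lacks the ether linker, gives > 10000 nM, a limit of the assay, so a cyano group does not bring a measured number in every compound shown.

Whether the gain is particular to cyano stays open, as no other group, such as an amine, a methoxy group or a carboxylic acid, appears at this position in the compounds shown. The full size of the chloro step also stays unknown, and only compound 2 and compound 4 give true numbers: the limit of > 10000 nM in this assay, at which 2 of the 4 values shown sit.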